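The source may report more compounds than this note shows. Statements on the series, on what has been measured and on what is new or still open speak of the compounds shown alone.

In a functional assay on MV4-11 cells (Homo sapiens) for antiproliferative activity, read by luminescence, with a stated time of 72 h (a lower number here means a stronger inhibitor, a higher number a weaker inhibitor), compound 1 (`C=CS(=O)(=O)NC/C=C/c1cc(OC)cc(O)c1C(=O)OC(C)C`) gives 4660 nM, and compound 2 (`C=CS(=O)(=O)NC/C=C/c1cc(OC)cc(O)c1C(=O)OCC1CCCCC1`) gives 5860 nM. Within the data shown here, compound 2 therefore stands within the scatter of the only other measured number. Compound 3 (`C=CS(=O)(=O)NC/C=C/c1cc(OC)cc(O)c1C(=O)OCc1ccc(Br)cc1`) keeps the shared core of compound 2 and carries 4-bromophenyl in place of cyclohexyl on a saturated chain carbon bound to an oxygen next to a carbonyl group. Among the measured compounds shown here, only one measured step bears on this change: a 1.3-fold higher number from compound 1 to compound 2 (0.10 log units; within the scatter). That step altered the group at the same oxygen and stayed within the scatter. However, no measured compound has an aromatic ring there, so the evidence is thin. No step beyond the scatter is expected in this assay, although the range must stay wide. The expected step is a 1.2-fold lower number from compound 2 to compound 3 (0.07 log units; within the scatter). Compound 3 is estimated at 5000 nM, with an expected range of 1800 nM to 14000 nM.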

Compound 3, half-maximal inhibitory concentration: 6060 nM
Compound 3: the middle estimate sits 1.2-fold (0.08 log units) below what was measured; the range from low to high includes it.
By their numbers in this assay, from the lowest: compounds 1, 2 and 3 (each within the scatter of the next).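

In this assay, 4-bromophenyl in place of cyclohexyl on a saturated chain carbon bound to an oxygen next to a carbonyl group gives a 1.0-fold higher number from compound 2 to compound 3 (0.01 log units; within the scatter), so an aromatic ring at this place reads the same as the saturated ring. Measured against isopropyl, 4-bromobenzyl gives a 1.3-fold higher number from compound 1 to compound 3 (0.11 log units; within the scatter), and the isopropyl, cyclohexylmethyl and 4-bromobenzyl esters therefore all lie within the scatter of one another, with even the added bromine-bearing ring leaving the number where it was. Nothing on hand gives a reason for this flat reading.

On these data alone, whether the reading stays flat for a free carboxylic acid in place of the ester remains open. As far as these compounds go, it is equally open whether a longer chain ending in an amine on this oxygen would move the number beyond the scatter.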